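A few compounds are considered here, and "the series" means these few. Any claim that something is new, unique, unknown or untested is made for them only; others in the source may bear on it.

Measured so far:
Compound 1 `CCCCCCCCCCCCCCCCCCCCCC(=O)OC[C@H]1O[C@@H](n2ccc(N)nc2=O)[C@@H](O)[C@@H]1O` — 0.04 ug/mL
Compound 2 `CCCCCCCCCC(=O)OC[C@H]1O[C@@H](n2ccc(N)nc2=O)[C@@H](O)[C@@H]1OC(=O)CCCCCCCCC` — 0.11 ug/mL

Two esters of the shared core have been run in a functional assay on HeLa cells (Homo sapiens) for cytotoxicity, read by cell counting, with a stated time of 48 h; a higher number here means that more compound is needed for the effect, a lower number that less compound is needed. Compound 1 carries a single long-chain ester and gives 0.04 ug/mL. Compound 2 carries two nonylcarbonyl esters and gives 0.11 ug/mL, the higher of the two numbers; the gap to compound 1 lies beyond the usual scatter, so compound 2 stands as the one needing more material.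

Compound 3 `CCCCCCCCCC(=O)OC[C@H]1O[C@@H](n2ccc(N)nc2=O)[C@@H](O)[C@@H]1O` has not yet been run in this assay. It follows from compound 2 by hydrogen in place of nonylcarbonyl on an oxygen on a saturated carbon, leaving a single nonylcarbonyl ester on the same oxygen that carries the ester in compound 1. Within the data shown here, no step between two measured compounds matches this change. Among the measured compounds shown here, the expected step of a 1.8-fold lower number from compound 2 to compound 3 (0.26 log units; within the scatter) in this assay is a moderate move toward a lower number, since the only single-ester compound measured, compound 1, gives 0.04 ug/mL, and compound 3 is not expected to fall outside what the two measured values bracket.

Compound 3 is estimated at 0.06 ug/mL, with a range from 0.02 ug/mL to 0.2 ug/mL.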

Compound 3, concentration for half-maximal effect: 0.1 ug/mL
Compound 3: the middle estimate sits 1.7-fold (0.22 log units) below what was measured; the range from low to high includes it.
By their numbers in this assay, from the lowest: compound 1; then compounds 3 and 2 (each within the scatter of the next).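

Going from (nonylcarbonyl)oxy to hydroxy on the oxygen on a saturated carbon gives in this assay a 1.1-fold lower number from compound 2 to compound 3 (0.04 log units; within the scatter), so at this position the second nonylcarbonyl ester and the free hydroxy cannot be told apart in this read-out. The chain of the remaining ester does register: hydrogen in place of dodecyl on a saturated chain carbon, nine bonds along the chain from a carbonyl carbon, gives a 2.5-fold higher number from compound 1 to compound 3 (0.40 log units; beyond the scatter), a modest step. Among these compounds, of the two single changes that can now be read, only this change in chain length lies beyond the scatter, so in these three compounds the number follows the length of that ester chain and not the presence of the second ester.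

No available evidence bears on what lies behind either step. Still open is whether the number keeps moving with a chain longer than that of compound 1 or with lengths that fall within the two chains shown, and whether an amine or a carboxylic acid at the chain end changes it, as is whether a second ester stays as silent when it carries the long chain.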